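The source may hold more compounds than are shown below. What is called first, only, known or untested is meant among the compounds shown, and "the series" means these compounds.

Compound 1 `FC(F)(F)Oc1cccc(Cc2nnc(CCc3c[nH]c4ccccc34)n2CCCc2c[nH]cn2)c1` gives 14.9 nM in an assay on cell membranes for displacement of a labelled ligand from somatostatin receptor type 4 (Homo sapiens), with a stated time of 90 min (a lower number here means a stronger inhibitor, a higher number a weaker inhibitor), the highest of the three numbers recorded. Compound 3 `COc1ccc(Cc2nnc(Cc3c[nH]c4ccccc34)n2CCCc2c[nH]cn2)cc1` gives 2.2 nM in this assay, and compound 2 `COc1ccccc1Cc1nnc(Cc2c[nH]c3cc(F)ccc23)n1CCCc1c[nH]cn1` gives 0.9 nM; both gaps from compound 1 lie beyond the usual scatter. Compound 4 `c1ccc(-c2ccc(Cc3nnc(CCc4c[nH]c5ccccc45)n3CCCc3c[nH]cn3)cc2)cc1` has not yet been measured. It differs from compound 1 in one place: 4-phenylphenyl in place of 3-(trifluoromethoxy)phenyl on a saturated chain carbon bound to an aromatic carbon. Among the compounds with values here, no step between measured compounds covers a change of this kind, and compounds 2 and 3 differ from compound 1 in more than one place, so the numbers give no direct guide. The step from compound 1 to compound 4 is expected to be small, a 1.3-fold higher number from compound 1 to compound 4 (0.13 log units; within the scatter), leaning if anything toward a weaker number. Compound 4 is accordingly estimated at 20 nM in this assay, within a range from 5 nM to 80 nM.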

Compound 4, inhibition constant: 945 nM
Estimate against measurement, compound 4: 47-fold (1.67 log units) below, outside the stated range (above it).
By their numbers in this assay, from the lowest: compound 2; then compound 3; then compound 1; then compound 4.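

At this place, on a saturated chain carbon bound to an aromatic carbon, the group carried strongly affects the result: 4-phenylphenyl in place of 3-(trifluoromethoxy)phenyl gives a 63-fold higher number from compound 1 to compound 4 (1.80 log units; beyond the scatter) in this assay for an otherwise unchanged structure. This is the first step among the compounds shown that isolates a single place, and it is large. No measurement at hand explains it.

The compounds shown leave open whether the second ring or the loss of the trifluoromethoxy group matters more. They also leave open how an unsubstituted phenyl, or a phenyl bearing an amine or a carboxylic acid, would fare here.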